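The compounds below may be only part of what the source reports. "The series", "measured", "known", "first", "only" and "open" are said of these compounds alone.

Measured in a functional assay on CWR22R cells (Homo sapiens) for antiproliferative activity, read by propidium iodide staining, with a stated time of 96 h; a lower number here means a stronger inhibitor, a higher number a weaker inhibitor:
compound 1 `CC(O)(CSc1ccc(C(F)(F)F)cc1)C(=O)Nc1ccc(S(F)(F)(F)(F)F)cc1` gives 14800 nM;
compound 2 `CC(O)(CSc1cccc(C(F)(F)F)c1)C(=O)Nc1ccc(S(F)(F)(F)(F)F)cc1` gives 23400 nM;
compound 3 `CC(O)(CSc1ccc(C(F)(F)F)cc1)C(=O)Nc1cccc(S(F)(F)(F)(F)F)c1` gives 26900 nM.

Compound 1 and compound 2 share a core and differ by one change, (3-(trifluoromethyl)phenyl in place of 4-(trifluoromethyl)phenyl on a sulfur). This change made a 1.6-fold higher number from compound 1 to compound 2 (0.20 log units; within the scatter), so the two values lie close together. Compound 4 `CC(O)(CSc1cccc(C(F)(F)F)c1)C(=O)Nc1cccc(S(F)(F)(F)(F)F)c1` has not been measured. It is related to compound 3 by the same change, (3-(trifluoromethyl)phenyl in place of 4-(trifluoromethyl)phenyl on a sulfur), made on the core of compound 3; the difference between the core of compound 3 and the core of compound 1 is not broken down here. Because the earlier step was a 1.6-fold higher number from compound 1 to compound 2 (0.20 log units; within the scatter), a step of similar size is expected from compound 3 to compound 4, namely a 1.4-fold higher number from compound 3 to compound 4 (0.15 log units; within the scatter). On this basis compound 4 is estimated to give 38000 nM in this assay, with a likely range from 18000 nM to 80000 nM.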

Compound 4, half-maximal inhibitory concentration: 12900 nM
Compound 4: middle estimate off by 2.9-fold (0.47 log units), on the high side; the measured number lies below the stated range.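

In this assay, 3-(trifluoromethyl)phenyl in place of 4-(trifluoromethyl)phenyl on a sulfur gave a 2.1-fold lower number from compound 3 to compound 4 (0.32 log units; beyond the scatter). Going by these compounds alone, the size and direction of this change's effect therefore do not carry over unchanged between these two cores: the same change on two cores in this assay, a 1.6-fold higher number (0.20 log units; within the scatter) from compound 1 to compound 2 and a 2.1-fold lower number (0.32 log units; beyond the scatter) from compound 3 to compound 4, 3.3-fold (0.52 log units) apart, beyond the scatter of two such steps This rests on only two pairs of compounds, and it shows neither why the two cores differ nor how the change would behave on any other core.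

All the compounds shown carry trifluoromethyl on the phenyl ring attached to the sulfur. On these data alone, whether a nitrile or a methoxy group there would show the same dependence on the core remains open, as does the effect of a sulfone in place of the sulfur.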